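The compounds below may be only part of what the source reports. "The series", "measured", "known", "first", "only" and "open" are said of these compounds alone.

Working notes on the series in a functional assay on DU-145 cells (Homo sapiens) for inhibition, read by trypan blue exclusion, with a stated time of 96 h; on this read-out lower numbers stand for stronger inhibition of growth and higher numbers for weaker inhibition of growth. Compound 1 (`Cc1ccc(CS/C(=C/c2c(O)cc(O)cc2O)C(=O)c2ccc(Cl)cc2)cc1`) gives 50000 nM and compound 3 (`Cc1ccc(CS/C(=C/c2ccc(O)c(O)c2O)C(=O)c2ccc(Cl)cc2)cc1`) gives 50000 nM, with no change at the digits printed from compound 1 to compound 3 (within the scatter). Compound 2 (`Cc1ccc(CS/C(=C/c2ccccc2F)C(=O)c2ccc(Cl)cc2)cc1`) gives 10000 nM, the lowest of the three numbers. Compound 4 (`Cc1ccc(CS/C(=C/c2ccccc2F)C(=O)c2ccc(Br)cc2)cc1`) changes only the halogen of compound 2: bromo in place of chloro on an aromatic carbon. This is bromo in place of chloro on an aromatic carbon, para to a large group. The measured steps, a 5.0-fold lower number from compound 1 to compound 2 (0.70 log units; beyond the scatter) and a 5.0-fold higher number from compound 2 to compound 3 (0.70 log units; beyond the scatter), both lie on the double-bonded chain carbon, and none of them changes the chloro group. They therefore give no direct guide to this change, and no shift beyond the scatter is expected. The expected step is no change at the digits printed from compound 2 to compound 4 (within the scatter). For compound 4 the estimate is 10000 nM, with an expected range of 4000 nM to 25000 nM.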

Compound 4, concentration for 50% growth inhibition: 10000 nM
The estimate for compound 4 equals the measured number at the digits printed; low and high end bracket the measured number.
By their numbers in this assay, from the lowest: compounds 2 and 4 (each within the scatter of the next); then compounds 1 and 3 (each within the scatter of the next).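

With the 2-fluorophenyl group held fixed, the first step read at this position, 4-bromophenyl in place of 4-chlorophenyl, gives no change at the digits printed from compound 2 to compound 4 (within the scatter) and so shows that one halogen can replace the other here without a shift beyond the scatter. The earlier steps shown here all lay on the double-bonded chain carbon and said nothing about this site. No measurement on hand explains why the two halogens read alike.

Still open, from the compounds shown here alone, is whether a non-halogen group here, such as an amine or a methoxy group, would move the number. Also open, going by these compounds, is whether the same halogen exchange reads alike when a trihydroxyphenyl group replaces the 2-fluorophenyl group.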